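The source may report more compounds than this note shows. Statements on the series, on what has been measured and on what is new or still open speak of the compounds shown alone.

Measured so far:
compound 1 `Nc1scc(CN2CCN(c3ccc(F)cc3F)CC2)c1C(=O)c1ccc(Cl)cc1` — 0%
compound 2 `Nc1scc(CN2CCN(c3ccccc3Cl)CC2)c1C(=O)c1ccc(Cl)cc1` — -2.1%

Going by the values given here, in a functional assay on CHO cells with adenosine receptor A1 (Homo sapiens) as the target, read by cAMP accumulation and immunoassay, with a stated time of 6 min, tested at 0.01 uM (a higher number here means a weaker effect of the compound at the concentration tested, a lower number a stronger effect), compound 1 gives 0% and compound 2 gives -2.1%; the two sit within the scatter of each other, and the only measured step, a number 2.1 percentage points lower from compound 1 to compound 2 (within the scatter), confirms that. Compound 3 `Nc1scc(CN2CCN(c3cc(Cl)ccc3Cl)CC2)c1C(=O)c1ccc(Cl)cc1` differs from compound 2 by chloro in place of hydrogen on an aromatic carbon. Among the compounds with values here, no measured step adds a chloro to this ring; the one step known swaps the whole aryl group and stays within the scatter, so the step of a number 1.1 percentage points higher from compound 2 to compound 3 (within the scatter) is expected to be none beyond the scatter. Compound 3 is therefore estimated at -1%, between -12% and 10%.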

Compound 3, a percentage reported as activity, at one concentration (the size of the read-out at that concentration, not a potency): 13%
Estimate against measurement, compound 3: 14 percentage points below; the whole stated range lies below it.
By their numbers in this assay, from the lowest: compounds 2 and 1 (each within the scatter of the next); then compound 3.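

In this assay, going by these compounds alone, the aryl group on the amine nitrogen now makes a difference: the chloro on the aromatic carbon para to a chloro group gives a number 15.1 percentage points higher from compound 2 to compound 3 (beyond the scatter) and is the first single change to pass the scatter. The 2,5-dichlorophenyl group also stands apart from 2,4-difluorophenyl, with a number 13 percentage points higher from compound 1 to compound 3 (beyond the scatter) on that swap. Nothing measured bears on the cause of this shift.
Open, on these data alone, is whether a methyl or methoxy group on the same carbon moves the number as chloro does. Also open, as far as these compounds go, is how a fluoro group there would read.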